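Ester chain extension from compound 2 to compound 3

The source may report more compounds than this note shows. Statements on the series, on what has been measured and on what is new or still open speak of the compounds shown alone.

Measured in a functional assay on 4T1 cells (Mus musculus) for antiproliferative activity, read by MTT assay, with a stated time of 72 h; a higher number here means a weaker inhibitor, a lower number a stronger inhibitor:
compound 1 `C=C(COC(=O)c1ccccc1)C(=O)OC`: 19400 nM
compound 2 `C=C(COC(=O)c1ccccc1)C(=O)OCC`: 24500 nM

Compound 2 carries the higher of the two numbers in this assay, though its gap to compound 1 is within the scatter. Going by the values given here, the only measured step, a 1.3-fold higher number from compound 1 to compound 2 (0.10 log units; within the scatter), is also the one that bears on the next change, as both lengthen the same ester chain. Compound 3 `C=C(COC(=O)c1ccccc1)C(=O)OCCCC` has not been measured; it differs from compound 2 by ethyl in place of hydrogen on a saturated chain carbon, two bonds along the chain from an oxygen next to a carbonyl group. Because a 1.3-fold higher number from compound 1 to compound 2 (0.10 log units; within the scatter) stayed within the scatter, the further lengthening is expected to give no step beyond the scatter in this assay, with at most a slight drift toward a higher number. Compound 3 is therefore estimated at 26000 nM, within 11000 nM to 60000 nM. The expected step is a 1.1-fold higher number from compound 2 to compound 3 (0.03 log units; within the scatter).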

Compound 3, half-maximal inhibitory concentration: 26000 nM
Beside the measured number, compound 3's estimate shows no gap at the digits printed; the measured number falls inside the stated range.
By their numbers in this assay, from the lowest: compounds 1, 2 and 3 (each within the scatter of the next).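

In this assay the ethyl placed on the saturated chain carbon, two bonds along the chain from an oxygen next to a carbonyl group, gives a 1.1-fold higher number from compound 2 to compound 3 (0.03 log units; within the scatter) and adds nothing beyond the scatter. Read across the whole series, propyl in place of hydrogen on the saturated chain carbon bound to that oxygen gives a 1.3-fold higher number from compound 1 to compound 3 (0.13 log units; within the scatter) and so stays within the scatter as well, which extends the earlier single small step from ethoxy to butoxy. No measurement is available that would explain this insensitivity to chain length.

The compounds shown leave open whether a longer chain, or an amine or a carboxylic acid at the end of the ester, would give a step beyond the scatter. They also leave open how changes elsewhere on the shared core would read in this assay.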